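A Second Fluoro Group Enters the Ring of Compound 3

A few compounds are considered here, and "the series" means these few. Any claim that something is new, unique, unknown or untested is made for them only; others in the source may bear on it.

Measured compounds:
compound 1, `CCOC(=O)c1cccc(NC(=O)N[C@H](C)c2ccccc2)c1`, 99%
compound 2, `COc1cccc(NC(=O)N[C@H](C)c2ccccc2)c1`, 104%
compound 3, `C[C@@H](NC(=O)Nc1cccc(F)c1)c1ccccc1`, 99%

The read-out is an ADME assay on the whole organism with Oryza sativa as the target, tested at 0.1 uM; a higher number here means a weaker effect of the compound at the concentration tested, a lower number a stronger effect. The three compounds share a core and differ only in one group on an aromatic ring, and the numbers barely move: a number 5 percentage points higher from compound 1 to compound 2 (within the scatter), no change at the digits printed from compound 1 to compound 3 (within the scatter) and a number 5 percentage points lower from compound 2 to compound 3 (within the scatter). Compound 3 therefore stands level with compound 1, and its gap to compound 2 lies within the scatter, so no order among the three can be claimed.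

Compound 4, `C[C@@H](NC(=O)Nc1ccc(F)c(F)c1)c1ccccc1`, comes from compound 3 by a small change: fluoro in place of hydrogen on an aromatic carbon. All three measured steps bear on it in the sense that each swapped one aromatic substituent for another and none left the scatter, but none of them added a second group to a ring that already carried one, so they speak to the new step only loosely. On that basis a step beyond the scatter in this assay is not expected; the estimated step is no change at the digits printed from compound 3 to compound 4 (within the scatter). Compound 4 is therefore expected to give about 99%, in a range from 88% to 108%.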

Compound 4, a percentage reported as activity, at one concentration (the size of the read-out at that concentration, not a potency): 99%
Compound 4: the middle estimate sits on the measured number at the digits printed; the range from low to high includes it.
By their numbers in this assay, from the lowest: compounds 1, 3, 4 and 2 (each within the scatter of the next).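

Every earlier step in this assay swapped one group on the aromatic ring for another, whereas compound 4 adds a group to a ring that already carries one, with the new fluoro ortho to a fluoro group and para to a large group. The step reads no change at the digits printed from compound 3 to compound 4 (within the scatter) and so, at the single concentration tested, this read-out does not separate hydrogen from fluoro at this position, even with a fluoro group already on the ring. No independent data are available to explain this result.

The compounds shown leave open whether a group other than fluoro at this same position, such as an amine, a carboxylic acid or a longer chain, would give a step beyond the scatter. They also leave open whether the four compounds, whose numbers all lie within the scatter of the next, would separate from one another at a higher concentration, since a reading at one concentration is the size of the effect there and not a potency.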